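Swapping the aryl group on the shared core of compound 3

The source may report more compounds than this note shows. Statements on the series, on what has been measured and on what is new or still open speak of the compounds shown alone.

Of the compounds shown here, three sharing one core have been tested in a functional assay on NCI-H226 cells (Homo sapiens) for inhibition, read by MTT assay, with a stated time of 48 h, tested at 10 uM; on this read-out lower numbers stand for less inhibition and higher numbers for more inhibition at the one concentration tested (going by the name of the read-out). Compound 1 `Cc1ccc(Nc2cc(NC(=O)Nc3c(Cl)cccc3Cl)ncn2)cc1F` gives 40.7%, compound 2 `COc1ccc(F)cc1Nc1cc(NC(=O)Nc2c(Cl)cccc2Cl)ncn1` gives 31.3%, and compound 3 `Cc1cc(F)cc(Nc2cc(NC(=O)Nc3c(Cl)cccc3Cl)ncn2)c1` gives 78.1%. Compound 3 stands highest of the three: the rise a number 37.4 percentage points higher from compound 1 to compound 3 (beyond the scatter) and the rise a number 46.8 percentage points higher from compound 2 to compound 3 (beyond the scatter) both lie beyond the scatter, while the drop a number 9.4 percentage points lower from compound 1 to compound 2 (within the scatter) does not. Compound 4 `COc1cc(Br)ccc1Nc1cc(NC(=O)Nc2c(Cl)cccc2Cl)ncn1` has not yet been measured. It differs from compound 3 at one place: 4-bromo-2-methoxyphenyl in place of 3-fluoro-5-methylphenyl on a nitrogen on an aromatic ring. The two measured steps that bear on this are the ones leading into compound 3, since both show that exchanging the 3-fluoro-5-methylphenyl for another aryl group on that nitrogen moved the inhibition by a large margin. Compound 2, which also carries a methoxy group on its aryl ring, sits at the bottom. A large fall is therefore expected for compound 4, a step of about a number 38.1 percentage points lower from compound 3 to compound 4 (beyond the scatter). Compound 4 is expected to give roughly 40%, within the range 20% to 65%.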

Compound 4, a percentage reported as inhibition, at one concentration (the size of the read-out at that concentration, not a potency): 43%
Estimate against measurement, compound 4: 3 percentage points below; low and high end bracket the measured number.
By their numbers in this assay, from the lowest: compounds 2, 1 and 4 (each within the scatter of the next, the first and the last beyond it); then compound 3.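

In this assay, a third replacement for the 3-fluoro-5-methylphenyl group on this nitrogen also costs a large amount of inhibition: a number 35.1 percentage points lower from compound 3 to compound 4 (beyond the scatter). Sharing a methoxy group does not make two aryl groups equivalent here, as a number 11.7 percentage points higher from compound 2 to compound 4 (beyond the scatter), a modest step that comes from changing only the other ring substituent and its place. A ring with a methoxy group and bromine can also match one with a methyl group and fluorine, with a number 2.3 percentage points higher from compound 1 to compound 4 (within the scatter).

No measurement shown here explains why these aryl groups differ. Going by these compounds, it remains open how a phenyl ring bearing an amine or a carboxylic acid would compare with the 3-fluoro-5-methylphenyl group of compound 3.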